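The compounds below may be only part of what the source reports. "The series", "measured", "known", "first", "only" and "open" are said of these compounds alone.

In an ADME assay on L929 cells (Mus musculus) for cytotoxicity, read by resazurin assay, with a stated time of 72 h (on this read-out lower numbers stand for stronger inhibition and higher numbers for weaker inhibition), compound 1 (`CCc1ccc(C(=O)/C=C/c2ccc3c(c2)B(O)OC3)cc1`) gives > 10 ug/mL as a limit of the assay, not a number. Compound 2 (`O=C(/C=C/c1ccc2c(c1)B(O)OC2)c1ccccc1O`) gives > 10 ug/mL, again only a limit. Within the data shown here, compound 3 (`Cc1cccc(C(=O)/C=C/c2ccc3c(c2)B(O)OC3)c1`) gives 8.56 ug/mL as the only true number so far. Compound 4 (`O=C(/C=C/c1ccc2c(c1)B(O)OC2)c1ccc(I)cc1`) keeps the shared core and carries 4-iodophenyl in place of 3-methylphenyl on a carbonyl carbon. One measured step changes the group at this place, an at least 1.1-fold lower number from compound 2 to compound 3 (0.06 log units; that floor lies within the scatter), and the wider picture is the limit of > 10 ug/mL in this assay, at which 2 of the 3 values shown sit. Among the measured compounds shown here, with that step as the only guide, no change beyond the scatter is expected, and the expected step is a 1.1-fold higher number from compound 3 to compound 4 (0.02 log units; within the scatter) in this assay. For compound 4 the estimated value is 9 ug/mL, with an expected range from 4 ug/mL to 20 ug/mL.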

Compound 4, half-maximal inhibitory concentration: > 10 ug/mL
Compound 4 was reported as a limit; the forecaster's own chance of this, stated with the estimate: 45%; at least 1.1-fold (0.04 log units) between middle value and limit.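

In this assay the swap to 4-iodophenyl in place of 3-methylphenyl on a carbonyl carbon gives an at least 1.1-fold higher number from compound 3 to compound 4 (0.06 log units; that floor lies within the scatter) and so shows no change that can be told from the scatter. Among these compounds, compound 4 is reported only as a limit, and compound 3 remains the only compound here with a true number: the limit of > 10 ug/mL in this assay, at which 3 of the 4 values shown sit. The steps to compound 4 from compound 1 and compound 2 join two limits and cannot be read. On these data alone, whether an amine or a carboxylic acid on this phenyl ring would give a clearly lower number than compound 3 stays open.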